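Amino in place of chloro: expected step in binding

A few compounds are considered here, and "the series" means these few. Any claim that something is new, unique, unknown or untested is made for them only; others in the source may bear on it.

Compound 3 `Clc1cncc(OC[C@@H]2CCN2)c1` stands lowest of the three measured compounds in an assay on brain for binding affinity to Neuronal acetylcholine receptor; alpha4/beta2 (Rattus norvegicus), read by radioligand binding (on this read-out higher numbers stand for weaker inhibition and lower numbers for stronger inhibition), giving 0.042 nM. The other two sit far above it: compound 1 `N#Cc1ccc(OC[C@@H]2CCN2)cn1` gives 1.9 nM, and compound 2 `c1ccc(-c2ccc(OC[C@@H]3CCN3)cn2)cc1` gives 2.3 nM. Among the compounds with values here, the single measured step, a 1.2-fold higher number from compound 1 to compound 2 (0.08 log units; within the scatter), concerns a different carbon of the shared core and so bears only loosely on the change at hand; it shows that the group at that other carbon hardly moves the number. Compound 4 `Nc1cncc(OC[C@@H]2CCN2)c1` differs from compound 3 by amino in place of chloro on an aromatic carbon. Within the data shown here, no measured pair covers a swap at this carbon; the only guide is that compound 3, carrying chloro here, sits well below compounds 1 and 2, which carry nothing at this carbon. Compound 4 is therefore expected to give a higher number than compound 3 in this assay, by a step of a 14-fold higher number from compound 3 to compound 4 (1.15 log units; beyond the scatter). The estimate for compound 4 in this assay is 0.6 nM, with a range from 0.1 nM to 3 nM.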

Compound 4, inhibition constant: 0.082 nM
The estimate for compound 4 lay 7.3-fold (0.86 log units) above the measured number; measured number outside the range, below it.
By their numbers in this assay, from the lowest: compounds 3 and 4 (each within the scatter of the next); then compounds 1 and 2 (each within the scatter of the next).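

In this assay, amino in place of chloro on this aromatic carbon, two atoms from the ring nitrogen, gives a 2.0-fold higher number from compound 3 to compound 4 (0.29 log units; within the scatter) and so leaves the reading unchanged within the scatter. The earlier compounds shown here held no pair at this carbon; this pair shows that chloro is not required here and that a group counted with a hydrogen-bond donor and acceptor can stand in place of one counted with neither. No measured evidence bears on why the two groups read alike.

Only chloro and amino are shown at this carbon, so a methoxy group, a carboxylic acid or a longer alkyl chain there remains an open case. On these data alone, whether amino and chloro also read alike on another aromatic carbon of the shared core remains open too.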